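This account rests on a few compounds, and the source may have more. Where it says the series, first, only, none or still open, it means among the compounds named here.

Measured in a functional assay on MCF7 cells (Homo sapiens) for cytotoxicity, read by sulforhodamine B assay; on this read-out higher numbers stand for weaker inhibition of growth and lower numbers for stronger inhibition of growth:
- Compound 1 `CC1=CC[C@@H]([C@@](C)(O)CCCC(C)(C)NC(=S)N/N=C\c2ccc(O)cc2)CC1`: 6230 nM
- Compound 2 `CC1=CC[C@@H]([C@@](C)(O)CCCC(C)(C)NC(=S)N/N=C\c2ccccc2[N+](=O)[O-])CC1`: 18600 nM
- Compound 3 `CC1=CC[C@@H]([C@@](C)(O)CCCC(C)(C)NC(=S)N/N=C\c2cccc([N+](=O)[O-])c2)CC1`: 6720 nM

Compound 1 stands at the low end of these numbers, level with compound 3: the data show a 1.1-fold higher number from compound 1 to compound 3 (0.03 log units; within the scatter), but also a 3.0-fold higher number from compound 1 to compound 2 (0.48 log units; beyond the scatter). Compound 4 `CC1=CC[C@@H]([C@@](C)(O)CCCC(C)(C)NC(=S)N/N=C\c2cccc(Cl)c2)CC1` has not yet been measured. It differs from compound 1 as follows: 3-chlorophenyl in place of 4-hydroxyphenyl on a carbon with a double bond to nitrogen. For the measured compounds named here, the closest precedent is the 3-nitrophenyl of compound 3, reached by the small step above. The 2-nitrophenyl of compound 2 is a more distant guide, and the data also show a 2.8-fold lower number from compound 2 to compound 3 (0.44 log units; beyond the scatter). Going by the values given here, no chlorine-bearing compound has been measured. In this assay, no step beyond the scatter is therefore expected, and the estimated step is a 1.1-fold lower number from compound 1 to compound 4 (0.05 log units; within the scatter). The estimate for compound 4 is 5500 nM, with an expected range of 2300 nM to 13000 nM.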

Compound 4, concentration for 50% growth inhibition: 7350 nM
The estimate for compound 4 lay 1.3-fold (0.13 log units) below the measured number, and the stated range covers the measured number.
By their numbers in this assay, from the lowest: compounds 1, 3 and 4 (each within the scatter of the next); then compound 2.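

In this assay, the 3-chlorophenyl of compound 4 stands level with the 4-hydroxyphenyl (a 1.2-fold higher number from compound 1 to compound 4 (0.07 log units; within the scatter)), and chloro on the aromatic carbon stands level with nitro (a 1.1-fold higher number from compound 3 to compound 4 (0.04 log units; within the scatter)). Compound 2 remains apart from this group, now also against the chlorine-bearing compound (a 2.5-fold lower number from compound 2 to compound 4 (0.40 log units; beyond the scatter)). No supporting measurement accounts for these levels. Going by these compounds, whether a 2-chlorophenyl would track the 2-nitrophenyl of compound 2 stays open. So does the outcome of placing an amine or a carboxylic acid on the phenyl ring.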